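This account rests on a few compounds, and the source may have more. Where it says the series, first, only, none or still open, it means among the compounds named here.

In a functional assay on HCT-116 cells (Homo sapiens) for inhibition (a lower number here means that less compound is needed, a higher number that more compound is needed for the effect), compound 1 (`COc1cc(N2CCNCC2)ccc1Nc1nc(NC2CCCCC2)c2nc[nH]c2n1`) gives 160 nM, compound 2 (`COc1cc(N2CCN(C(=O)N3CCN(C)CC3)CC2)ccc1Nc1nc(NC2CCCCC2)c2nc[nH]c2n1`) gives 18 nM and compound 3 (`COc1cc(N2CCN(Cc3ccccn3)CC2)ccc1Nc1nc(NC2CCCCC2)c2nc[nH]c2n1`) gives 89 nM. Compound 3 therefore lies within the scatter of compound 1 and well clear of compound 2, with a 4.9-fold higher number from compound 2 to compound 3 (0.69 log units; beyond the scatter). Compound 4 (`COc1cc(N2CCN(CC3CCOC3)CC2)ccc1Nc1nc(NC2CCCCC2)c2nc[nH]c2n1`) has oxolan-3-yl in place of pyridin-2-yl on a saturated chain carbon bound to an amine nitrogen in a ring. Going by the values given here, no measured step makes this exact swap. The closest evidence is adding (pyridin-2-yl)methyl, which gave a 1.8-fold lower number from compound 1 to compound 3 (0.25 log units; within the scatter), a step within the scatter. The larger 8.9-fold lower number from compound 1 to compound 2 (0.95 log units; beyond the scatter) involved a different group, (4-methylpiperazin-1-yl)carbonyl. In this assay the expected step is a 1.1-fold higher number from compound 3 to compound 4 (0.05 log units; within the scatter), none beyond the scatter. Compound 4 is estimated at 100 nM, with an expected range from 40 nM to 250 nM.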

Compound 4, half-maximal effective concentration: 170 nM
Estimate against measurement, compound 4: 1.7-fold (0.23 log units) below; the measured number falls inside the stated range.
By their numbers in this assay, from the lowest: compound 2; then compounds 3, 1 and 4 (each within the scatter of the next).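

In this assay, oxolan-3-yl on this saturated chain carbon reads the same as pyridin-2-yl (a 1.9-fold higher number from compound 3 to compound 4 (0.28 log units; within the scatter)), so an aromatic ring is not required here. The (oxolan-3-yl)methyl group also reads the same as the hydrogen it replaces (a 1.1-fold higher number from compound 1 to compound 4 (0.03 log units; within the scatter)), whereas the step from (4-methylpiperazin-1-yl)carbonyl is large (a 9.4-fold higher number from compound 2 to compound 4 (0.98 log units; beyond the scatter)), so neither ring type matches that group. Nothing measured here explains these steps. Still open, from the compounds shown here alone, is what a (4-methylpiperazin-1-yl)methyl group would give, and so whether the carbonyl or the methylpiperazine matters more.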